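Fluoro in Place of Methyl on the Sulfonamide Aryl Ring

This account rests on a few compounds, and the source may have more. Where it says the series, first, only, none or still open, it means among the compounds named here.

Going by the values given here, in an ADME assay on MT4 cells (Homo sapiens) for cytotoxicity, read by MTT assay, with a stated time of 5 days (on this read-out lower numbers stand for higher toxicity in this test and higher numbers for lower toxicity in this test), compound 2 `Cc1ccc(S(=O)(=O)Nc2ccnc(Nc3ccc(C#N)cc3)n2)cc1` gives 130000 nM, the highest of the two numbers measured so far, and compound 1 `CC(C)(C)c1ccc(S(=O)(=O)Nc2ccnc(Nc3ccc(C#N)cc3)c2)cc1` gives 29300 nM, a lower number whose gap to compound 2 lies beyond the scatter. Compound 3 `N#Cc1ccc(Nc2nccc(NS(=O)(=O)c3ccc(F)cc3)n2)cc1` is the untested neighbour of compound 2, differing by fluoro in place of methyl on an aromatic carbon. Among the compounds with values here, no step of this kind has been measured here, so the expected step of a 1.3-fold lower number from compound 2 to compound 3 (0.11 log units; within the scatter) is small, probably within the scatter, if anything toward a slightly lower number. Compound 3 is therefore expected to give about 100000 nM, within a range from 40000 nM to 250000 nM.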

Compound 3, half-maximal cytotoxic concentration: 36600 nM
Compound 3: the middle estimate sits 2.7-fold (0.44 log units) above what was measured; measured number below the stated range.
By their numbers in this assay, from the lowest: compounds 1 and 3 (each within the scatter of the next); then compound 2.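

In this assay, going by these compounds alone, fluoro in place of methyl gives a 3.6-fold lower number from compound 2 to compound 3 (0.55 log units; beyond the scatter), the first measured step at this place on the ring. A lower number means higher toxicity in this test, so swapping a single atom on the 4-methylphenyl group is enough to shift the read-out beyond the scatter. No measurement shown here explains this shift.
On these data alone, whether chloro, methoxy or an amine at this place would give a higher or lower number remains open. So does whether the same change would produce a similar step on the core of compound 1.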